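Toward compound 4: a para-ethoxy variant of a shared core

A few compounds are considered here, and "the series" means these few. Any claim that something is new, unique, unknown or untested is made for them only; others in the source may bear on it.

Measured compounds:
- Compound 1 `Cc1cccc(-n2nncc2CN2C(=O)C3(C(C#N)=C(N)Oc4c(N)cc5nc6ccccc6nc5c43)c3ccccc32)c1`: > 50000 nM
- Compound 2 `CCc1ccccc1-n1nncc1CN1C(=O)C2(C(C#N)=C(N)Oc3c(N)cc4nc5ccccc5nc4c32)c2ccccc21`: 10300 nM
- Compound 3 `COc1ccccc1-n1nncc1CN1C(=O)C2(C(C#N)=C(N)Oc3c(N)cc4nc5ccccc5nc4c32)c2ccccc21`: > 50000 nM

All three share one core and differ only in the phenyl group attached to the triazole nitrogen. In a functional assay on HCT-116 cells (Homo sapiens) for antiproliferative activity, read by MTT assay, with a stated time of 48 h (on this read-out higher numbers stand for weaker inhibition and lower numbers for stronger inhibition), compound 3 gives > 50000 nM, which is a limit of the assay rather than a number. Compound 1 likewise sits at a limit, (the limit of > 50000 nM in this assay, at which 2 of the 3 values shown sit). Among the compounds with values here, compound 2 is the only one with a measured number, and the change from ethyl to methoxy gives an at least 4.8-fold higher number from compound 2 to compound 3 (0.68 log units; beyond the scatter), while a step that the two limits leave unreadable from compound 1 to compound 3 cannot be read.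

Compound 4 `CCOc1ccc(-n2nncc2CN2C(=O)C3(C(C#N)=C(N)Oc4c(N)cc5nc6ccccc6nc5c43)c3ccccc32)cc1` is not yet measured. It differs from compound 3 as 4-ethoxyphenyl in place of 2-methoxyphenyl on an aromatic nitrogen. Within the data shown here, no measured step involves a 4-ethoxyphenyl group, so nothing shows directly what this change does; the only nearby information is that compound 3 and compound 1 both sit at the limit. Compound 4 is therefore expected to stay near that limit, with an at least 1.2-fold lower number from compound 3 to compound 4 (0.09 log units; that floor lies within the scatter) expected to be small. The expected value for compound 4 is 40000 nM, between 8000 nM and 100000 nM.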

Compound 4, half-maximal inhibitory concentration: > 50000 nM
Compound 4: only a limit was reported; the forecaster's own chance of this, stated with the estimate: 60%; middle value at least 1.2-fold (0.09 log units) from the limit.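

In this assay compound 4 gives > 50000 nM, which is a limit of the assay and not a number. Putting 4-ethoxyphenyl in place of 2-ethylphenyl on the aromatic nitrogen gives an at least 4.8-fold higher number from compound 2 to compound 4 (0.68 log units; beyond the scatter), so a second oxygen-bearing group, after the 2-methoxyphenyl of compound 3, fails to reach the measured number of compound 2. The steps to compound 4 from compound 1 and compound 3 cannot be read, and compound 2 remains the only compound here with a number: the limit of > 50000 nM in this assay, at which 3 of the 4 values shown sit.

The compounds shown leave open whether the number for compound 2 depends on the ethyl group itself or on where it sits on the phenyl ring, a question that 4-ethylphenyl and 2-ethoxyphenyl could separate. They also leave open whether a longer chain, such as 2-propylphenyl, or a phenyl ring carrying an amine would give a number in this assay.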